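The source may report more compounds than this note shows. Statements on the series, on what has been measured and on what is new or still open speak of the compounds shown alone.

Measured in a functional assay on Maver1 cells (Homo sapiens) for inhibition, read by luminescence and CellTiter-Glo, with a stated time of 72 h; on this read-out lower numbers stand for stronger inhibition and higher numbers for weaker inhibition:
- compound 1 `O=C(CCl)N1CCCC(n2nc(-c3ccc(Oc4ccccc4)cc3)cc2CO)C1`: 1100 nM
- compound 2 `C=CC(=O)N1CCCC(n2nc(-c3ccc(Oc4ccccc4)cc3)cc2C(=O)O)C1`: > 60000 nM (a limit)
- compound 3 `C/C=C/C(=O)N1CCCC(n2nc(-c3ccc(Oc4ccccc4)cc3)cc2CO)C1`: > 60000 nM (a limit)

Compound 3 gives no exact number and sits at the limit of > 60000 nM in this assay, at which 2 of the 3 values shown sit. As far as these compounds go, its true position beyond that limit is unknown, so any step starting from compound 3 can only be estimated loosely.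

Compound 4 `C=CC(=O)N1CCCC(n2nc(-c3ccc(Oc4ccccc4)cc3)cc2CO)C1` differs from compound 3 in one place: vinyl in place of prop-1-en-1-yl on a carbonyl carbon. That is, vinyl takes the place of prop-1-en-1-yl on a carbonyl carbon.

For the measured compounds named here, one measured step concerns this same carbonyl carbon. Swapping chloromethyl for prop-1-en-1-yl gives an at least 54-fold higher number from compound 1 to compound 3 (1.73 log units; beyond the scatter), which is a large loss, so the group at this carbon can strongly move the read-out. Removing prop-1-en-1-yl may therefore recover inhibition, but vinyl itself offers no guarantee. Compound 2 also carries vinyl there, though it differs from compound 4 elsewhere on the core. Compound 2 reads > 60000 nM, which is a limit.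

The expected change is an at least 20-fold lower number from compound 3 to compound 4 (1.30 log units; beyond the scatter), a large move towards stronger inhibition, although another limit remains possible.

For compound 4 the estimated value is 3000 nM, with an expected range of 500 nM to 30000 nM.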

Compound 4, half-maximal inhibitory concentration: 30500 nM
Beside the measured number, compound 4's estimate is 10-fold (1.01 log units) below it; measured number above the stated range.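

In this assay, the step of a 28-fold higher number from compound 1 to compound 4 (1.44 log units; beyond the scatter) gives the first exact size for a change at this carbonyl carbon: vinyl in place of chloromethyl costs a large amount of inhibition, whereas the earlier step to prop-1-en-1-yl gave only a floor. The steps of an at least 1.9-fold lower number from compound 3 to compound 4 (0.29 log units; that floor lies within the scatter) and an at least 1.9-fold lower number from compound 2 to compound 4 (0.29 log units; that floor lies within the scatter) are floors that lie within the scatter, so they show no clear gain for vinyl over prop-1-en-1-yl, or for hydroxymethyl over carboxy on the aromatic carbon. Compound 2 and compound 3 each give only a limit, so how far compound 4 truly lies from them stays unknown: the limit of > 60000 nM in this assay, at which 2 of the 4 values shown sit.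

The compounds shown leave open how other groups on this carbonyl carbon, such as bromomethyl or a plain methyl, would compare with chloromethyl and vinyl. They also leave open how an amine or an ester in place of hydroxymethyl on the aromatic carbon would read, and whether chloromethyl on the carbonyl carbon would keep its inhibition with carboxy on that aromatic carbon.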